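A few compounds are considered here, and "the series" means these few. Any claim that something is new, unique, unknown or untested is made for them only; others in the source may bear on it.

Of the compounds shown here, three sharing a core have been measured in a functional assay on MCF7 cells (Homo sapiens) for inhibition; a higher number here means a weaker inhibitor, a lower number a stronger inhibitor. Compound 1 `N#CC1CN1C(=O)Nc1ccc(Cl)c(Cl)c1` gives 4400 nM, compound 2 `CC(=O)c1cccc(NC(=O)N2CC2C#N)c1` gives 3500 nM, and compound 3 `N#CC1CN1C(=O)Nc1ccc([N+](=O)[O-])cc1` gives 3000 nM. Compound 3 shows the lowest of the three numbers, yet its gaps to compound 2 and to compound 1 both fall within the usual scatter, so the three cannot be ordered against one another. Compound 4 `N#CC1CN1C(=O)Nc1ccc(F)cc1` differs from compound 3 in one place: fluoro in place of nitro on an aromatic carbon. Going by the values given here, no step between measured compounds isolates such a change, and the three measured values sit in a narrow band. Compound 4 is therefore estimated at 4500 nM, within 2000 nM to 10000 nM. This amounts to an expected step of a 1.5-fold higher number from compound 3 to compound 4 (0.18 log units; within the scatter), expected to stay within or only just beyond the scatter, leaning toward a slightly higher number.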

Compound 4, half-maximal inhibitory concentration: 2700 nM
Estimate against measurement, compound 4: 1.7-fold (0.22 log units) above; measured number inside the range.
By their numbers in this assay, from the lowest: compounds 4, 3, 2 and 1 (each within the scatter of the next).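

In this assay fluoro in place of nitro on the aromatic carbon gives a 1.1-fold lower number from compound 3 to compound 4 (0.05 log units; within the scatter) and so leaves compound 3 and compound 4 indistinguishable. Going by these compounds alone, at this position, para to a group of 8 heavy atoms, a single fluorine and a nitro group with its two hydrogen-bond acceptors thus read alike, which the earlier compounds could not show. No evidence available here speaks to the reason. From the compounds shown here alone, whether an amine or a carboxylic acid on this carbon would stay in the same band remains open, as does whether any group here moves the number beyond the scatter.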